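Indole chain terminus: cyanosulfanyl to ethylcarbamoyl

The compounds below may be only part of what the source reports. "The series", "measured", "known", "first", "only" and "open" are said of these compounds alone.

Measured so far in an assay on isolated protein for inhibition of Myeloperoxidase (Homo sapiens), read by ELISA, with a stated time of 5 min; a lower number here means a stronger inhibitor, a higher number a weaker inhibitor:
compound 1, `NC(=O)CCCCc1c[nH]c2ccc(F)cc12`, gives 43 nM.
compound 2, `CCCc1c[nH]c2ccc(F)cc12`, gives a limit of the assay, > 100 nM.
compound 3, `N#CSCCCc1c[nH]c2ccc(F)cc12`, gives 23 nM.

Compound 3 holds the lowest of the two numbers shown; its nearest neighbour is compound 1, a 1.9-fold lower number from compound 1 to compound 3 (0.27 log units; within the scatter), a gap within the scatter. Against the limit of compound 2 the step is an at least 4.3-fold lower number from compound 2 to compound 3 (0.63 log units; beyond the scatter), so the cyanosulfanyl end of the chain does matter relative to bare hydrogen. The reverse view, an at least 2.3-fold higher number from compound 1 to compound 2 (0.36 log units; beyond the scatter), shows the same for the carbamoylmethyl end, which rests on (the limit of > 100 nM in this assay, at which 1 of the 3 values shown sits).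

Compound 4, `CCNC(=O)CCCc1c[nH]c2ccc(F)cc12`, differs from compound 3 in one place: ethylcarbamoyl in place of cyanosulfanyl on a saturated chain carbon, three bonds along the chain from an aromatic carbon. Compound 4 is thus closer in kind to compound 1 than to compound 3, carrying a carbonyl-bearing terminus with one hydrogen-bond donor where compound 3 carries none. Going by the values given here, the only direct guide is the step from compound 1 to compound 3, which lay within the scatter, so a return to an amide-type terminus is not expected to move the number beyond the scatter in either direction. For compound 4 in this assay the estimate is 40 nM, within 15 nM to 110 nM, meaning an expected 1.7-fold higher number from compound 3 to compound 4 (0.24 log units; within the scatter).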

Compound 4, half-maximal inhibitory concentration: 243 nM
Compound 4: the middle estimate sits 6.1-fold (0.78 log units) below what was measured; measured number above the stated range.
By their numbers in this assay, from the lowest: compounds 3 and 1 (each within the scatter of the next); then compound 4.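

In this assay, this position responds to the nature of the terminus and not only to whether one is present: an 11-fold higher number from compound 3 to compound 4 (1.02 log units; beyond the scatter). The earlier compounds shown here left compound 1 and compound 3 within the scatter of each other, but that closeness does not extend to every carbonyl-bearing terminus, and the carbamoylmethyl and ethylcarbamoyl groups are not interchangeable here: a 5.7-fold higher number from compound 1 to compound 4 (0.75 log units; beyond the scatter). Compound 2 carries a limit, and its step to compound 4 cannot be read, so the series does not show whether the ethylcarbamoyl terminus offers any gain over the propyl chain of compound 2: the limit of > 100 nM in this assay, at which 1 of the 4 values shown sits.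

The compounds shown leave open whether the loss in compound 4 belongs to the ethyl group on the amide nitrogen or to the amide terminus as a whole. A methylcarbamoyl group, a carboxylic acid, an amine or a longer chain carrying the cyanosulfanyl group, on the same saturated chain carbon, would help to show how narrow the tolerance at this position is and whether the cyanosulfanyl end has any special standing.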